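A few compounds are considered here, and "the series" means these few. Any claim that something is new, unique, unknown or untested is made for them only; others in the source may bear on it.

Working notes on the series. Of the compounds shown here, two have been measured in a functional assay on MDA-MB-231 cells (Homo sapiens) for inhibition, read by sulforhodamine B assay, with a stated time of 48 h (on this read-out lower numbers stand for stronger inhibition of growth and higher numbers for weaker inhibition of growth), so far. Compound 1 `N=C(N)c1ccc(-c2ccc(-c3ccc(Cl)cc3)s2)s1` gives 1800 nM. Compound 2 `COc1cc(OC)cc(-c2ccc(-c3ccc(C(=N)N)o3)o2)c1`, built on a different core, gives 2350 nM in this assay. Compound 1 holds the lowest of the two numbers, but the nearest compound, compound 2, lies within the usual scatter of it, so no order between the two is claimed.

Going by the values given here, no pair of measured compounds differs in a single place, so the series itself gives no step sizes to lean on.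

Compound 3 `N=C(N)c1ccc(-c2ccc(-c3ccc(F)cc3)s2)s1` keeps the core of compound 1 and differs from it in one place: fluoro in place of chloro on an aromatic carbon. Among the compounds with values here, with no measured step of this kind available, the expectation rests on the general run of such exchanges: a small step from compound 1 to compound 3, most likely none beyond the scatter, with any drift toward a somewhat higher number. The step is estimated at a 1.4-fold higher number from compound 1 to compound 3 (0.14 log units; within the scatter). For compound 3 in this assay a value of 2500 nM is expected, within a range from 1200 nM to 5500 nM.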

Compound 3, concentration for 50% growth inhibition: 1740 nM
Estimate against measurement, compound 3: 1.4-fold (0.16 log units) above; low and high end bracket the measured number.
By their numbers in this assay, from the lowest: compounds 3, 1 and 2 (each within the scatter of the next).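

Going by these compounds alone, the exchange gives the first measured step: in this assay the change is a 1.0-fold lower number from compound 1 to compound 3 (0.01 log units; within the scatter) and it sets no order between the two compounds. On an aromatic carbon of a six-membered aromatic ring of carbon only, para to a large group, chloro and fluoro are thus interchangeable on this read-out, although this single pair is the only support for that statement and it covers only these two groups on the core of compound 1. No measurement is available that bears on why the two groups fall so close together.

On these data alone, it remains open whether this flat response extends to groups of another kind at the same position, such as an amine, a hydroxyl, a carboxylic acid or a longer alkyl chain, any of which could show whether the position responds at all. Within the data shown here, the role of the core also remains open, since compound 2 differs from compound 1 in more than one place and no single-change step links it to the other two compounds.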